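This account rests on a few compounds, and the source may have more. Where it says the series, first, only, none or still open, it means among the compounds named here.

In an assay for inhibition of serine/threonine-protein kinase PAK 4 (Homo sapiens), read by FRET and Z'-LYTE, with a stated time of 60 min, tested at 50 uM, in the presence of a further agent that is not named here (on this read-out higher numbers stand for a stronger effect at the one concentration tested and lower numbers for a weaker effect), compound 1 `CCOC(=O)N1CCN(C(=O)c2nc(Nc3cc(C4CC4)[nH]n3)c3cc(Cl)ccc3n2)C[C@H]1C` gives 93.4%, the higher of the two measured numbers. Compound 2 `CC(OC(=O)C(C)C)OC(=O)N1CCN(C(=O)c2nc(Nc3cc(C4CC4)[nH]n3)c3cc(Cl)ccc3n2)C[C@H]1C` gives 71.7% in this assay, and the measured step of a number 21.7 percentage points lower from compound 1 to compound 2 (beyond the scatter) is the only one that bears on the present case. Compound 3 `CC(OC(=O)N1CCN(C(=O)c2nc(Nc3cc(C4CC4)[nH]n3)c3cc(Cl)ccc3n2)C[C@H]1C)OC(=O)C(C)(C)C` differs from compound 1 by ((tert-butyl)carbonyl)oxy in place of hydrogen on a saturated chain carbon bound to an oxygen next to a carbonyl group and a saturated chain carbon, a change of the same kind as that from compound 1 to compound 2. A modest downward step is therefore expected for compound 3, namely a number 23.4 percentage points lower from compound 1 to compound 3 (beyond the scatter). The estimate for compound 3 is 70%, with a range from 50% to 88%.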

Compound 3, a percentage reported as inhibition, at one concentration (the size of the read-out at that concentration, not a potency) in the serine/threonine-protein kinase PAK 4 assay: 65.3%
Compound 3: middle estimate off by 4.7 percentage points, on the high side, within the range that was stated.
By their numbers in the serine/threonine-protein kinase PAK 4 assay, from the lowest: compounds 3 and 2 (each within the scatter of the next); then compound 1.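

On this saturated chain carbon, ((tert-butyl)carbonyl)oxy also lowers the reading in the serine/threonine-protein kinase PAK 4 assay, giving a number 28.1 percentage points lower from compound 1 to compound 3 (beyond the scatter), while the further methyl that separates the two esters gives a number 6.4 percentage points lower from compound 2 to compound 3 (within the scatter), so those two esters cannot be told apart. In a physicochemical assay, read by HPLC, in phosphate buffer, with a stated time of 2 h, at pH 7.4 (on this read-out lower numbers stand for a less stable compound and higher numbers for a more stable compound), compound 1 gives 97.7% and compound 3 gives 90.5%, which is a number 7.2 percentage points lower from compound 1 to compound 3 (within the scatter). Nothing measured here explains the drop in inhibition. As far as these compounds go, whether an ester carrying an amine or a carboxylic acid on this carbon would keep the inhibition of compound 1 remains open.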